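Working notes: fluorine position on the biaryl arm and Vero cytotoxicity

This account rests on a few compounds, and the source may have more. Where it says the series, first, only, none or still open, it means among the compounds named here.

Measured so far in a toxicity assay on Vero cells (Chlorocebus sabaeus) for cytotoxicity; on this read-out higher numbers stand for lower toxicity in this test and lower numbers for higher toxicity in this test:

Compound 1, `COc1nc(-c2cccc(Cl)c2)ccc1[C@@H](c1ccccc1)[C@@](O)(CCN(C)C)c1cccc2ccccc12`, gives > 50 ug/mL, a limit of the assay.
Compound 2, `COc1nc(-c2ccc(F)cc2)ccc1[C@@H](c1ccccc1)[C@@](O)(CCN(C)C)c1cccc2ccccc12`, gives > 50 ug/mL, a limit of the assay.
Compound 3, `COc1ncc(-c2ccccc2)cc1[C@@H](c1ccccc1)[C@@](O)(CCN(C)C)c1cccc2ccccc12`, gives > 50 ug/mL, a limit of the assay.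

Compound 2 thus stands at the top of what this test can report: its value is a limit, not a number, and every other value in the set is a limit of the same kind (the limit of > 50 ug/mL in this assay, at which 3 of the 3 values shown sit). Among the measured compounds shown here, the one directly comparable pair is the step that the two limits leave unreadable from compound 1 to compound 2, which the two limits leave unreadable; no size can be taken from it.

Compound 4, `COc1nc(-c2cccc(F)c2)ccc1[C@@H](c1ccccc1)[C@@](O)(CCN(C)C)c1cccc2ccccc12`, is the next compound, differing from compound 2 in one place: 3-fluorophenyl in place of 4-fluorophenyl on an aromatic carbon. Only compound 1 and compound 2 bear on this change, and their step gave no readable size, so no step beyond the scatter is expected in this assay from compound 2 to compound 4, and the most likely outcome is again a limit. Compound 4 is therefore estimated at 70 ug/mL, within 40 ug/mL to 150 ug/mL, which corresponds to an expected step that the limit leaves unreadable from compound 2 to compound 4.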

Compound 4, half-maximal cytotoxic concentration: > 50 ug/mL
Compound 4: a limit, no number (the forecaster's own chance of this, stated with the estimate: 85%); the middle value lies beyond the limit too.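

In this assay no step can be read among compound 1, compound 2 and compound 4, since each value is a limit of the assay: the limit of > 50 ug/mL in this assay, at which 4 of the 4 values shown sit.

The compounds shown leave open how far any of these values lies beyond that limit, and whether 3-fluorophenyl in place of 4-fluorophenyl changes cytotoxicity at all.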